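Removing the acyl group from the ring nitrogen of compound 3

The compounds below may be only part of what the source reports. "The series", "measured", "known", "first", "only" and "open" are said of these compounds alone.

Compound 1 `Cc1nc2c(OCc3ccccc3)cccn2c1N`: 99%
Compound 2 `COC(=O)Nc1c(C)nc2c(OCc3ccccc3)cccn12`: 0%
Compound 3 `CNC(=O)Nc1c(C)nc2c(OCc3ccccc3)cccn12`: 22%

In a functional assay on the whole organism with Rattus norvegicus as the target, at a dose of 40 mg/kg by the intraperitoneal route (on this read-out lower numbers stand for less inhibition and higher numbers for more inhibition at the one dose given (going by the name of the read-out)), compound 3 gives 22%, the second highest of the three numbers. Its nearest neighbour is compound 2, with a number 22 percentage points higher from compound 2 to compound 3 (beyond the scatter); its furthest is compound 1, with a number 77 percentage points lower from compound 1 to compound 3 (beyond the scatter). Compound 4 `Cc1nc2c(OCc3ccccc3)cccn2c1NC(C)C` is not yet measured. It differs from compound 3 in one place: isopropyl in place of methylcarbamoyl on a nitrogen on an aromatic ring.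

For the measured compounds named here, two measured steps bear on this change. Both steps that put a carbonyl-bearing group on that nitrogen cut the read-out sharply: a number 99 percentage points lower from compound 1 to compound 2 (beyond the scatter) and a number 77 percentage points lower from compound 1 to compound 3 (beyond the scatter). The step from compound 4 back towards compound 3 is the reverse of such an acylation, since the methylcarbamoyl leaves and a plain isopropyl enters, so a large step upward is expected. The modest step of a number 22 percentage points higher from compound 2 to compound 3 (beyond the scatter) shows that the kind of carbonyl group matters less than its presence. Going by the values given here, no measured compound carries an alkyl on that nitrogen, so how far the rise reaches toward compound 1 is uncertain. The expected step is a number 53 percentage points higher from compound 3 to compound 4 (beyond the scatter). Compound 4 is therefore estimated at 75%, with a range from 35% to 99%.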

Compound 4, a percentage reported as inhibition, in the whole organism at one dose (the size of the read-out at that dose, not a potency): 18%
The estimate for compound 4 lay 57 percentage points above the measured number, and the stated range ends above it.
By their numbers in this assay, from the lowest: compound 2; then compounds 4 and 3 (each within the scatter of the next); then compound 1.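

In this assay, the large loss seen on going from hydrogen on this nitrogen on an aromatic ring to a carbonyl-bearing group is not confined to such groups: isopropyl, which has no carbonyl, gives a number 81 percentage points lower from compound 1 to compound 4 (beyond the scatter). Exchanging methylcarbamoyl for isopropyl gives a number 4 percentage points lower from compound 3 to compound 4 (within the scatter), while exchanging methoxycarbonyl for isopropyl gives a number 18 percentage points higher from compound 2 to compound 4 (beyond the scatter), so among the three substituted compounds only compound 2 stands apart from compound 4, and all three lie far from compound 1, with none going against that pattern. Nothing measured here explains why hydrogen on this nitrogen stands apart from all three groups.

On these data alone, what remains open is whether a methyl or an ethyl on this nitrogen would give a number near that of compound 1 or near that of compound 4, and whether a longer chain or a second alkyl group would read like isopropyl. With a single dose as the read-out, these numbers also leave open how the compounds would compare at other doses.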